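One Inverted Stereocentre at an Assay Limit

This account rests on a few compounds, and the source may have more. Where it says the series, first, only, none or still open, it means among the compounds named here.

Measured compounds:
- compound 1 `Cc1c2c(n3c1CCN(C(=O)[C@H](C)N)CC[C@H](C)Nc1cc-3ccc1C(N)=O)CC(C)(C)CC2=O`: > 100 ug/mL
- compound 2 `Cc1c2c(n3c1CCCNC[C@H](C)Nc1cc-3ccc1C(N)=O)CC(C)(C)CC2=O`: > 100 ug/mL
- compound 3 `Cc1c2c(n3c1CCCN(C(=O)[C@@H](C)N)[C@H](C)CNc1cc-3ccc1C(N)=O)CC(C)(C)CC2=O`: > 100 ug/mL

These three readings come from a physicochemical assay for solubility; a lower number here means a less soluble compound, a higher number a more soluble compound. None of them is an exact number, and all share one limit: the limit of > 100 ug/mL in this assay, at which 3 of the 3 values shown sit. Compound 1 therefore stands at > 100 ug/mL, which is a limit of the assay. The measurements do not place it in order against compound 2 or compound 3.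

Compound 4 `Cc1c2c(n3c1CCN(C(=O)[C@@H](C)N)CC[C@H](C)Nc1cc-3ccc1C(N)=O)CC(C)(C)CC2=O` is the next compound to consider. It is built from the same parts as compound 1, and only its drawn three-dimensional arrangement differs: the two compounds have the same atoms and bonds and differ only in configuration as drawn: 1 of 2 stereo elements differ; a stereocentre at a saturated chain carbon is drawn S in compound 1 and R in compound 4. In words, a stereocentre at a saturated chain carbon is drawn S in compound 1 and R in compound 4. No atom or bond enters or leaves.

Among the measured compounds shown here, no measured pair in this small set shows what such an inversion does in this assay. For the measured compounds named here, with no such step to draw on, no change beyond the usual scatter is expected, in either direction. The most likely outcome is another limit rather than an exact number. The expected change is a step that the limit leaves unreadable from compound 1 to compound 4. For compound 4, the estimated value is 130 ug/mL, with an expected range of 70 ug/mL to 260 ug/mL.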

Compound 4, solubility: > 100 ug/mL
Compound 4 gave a limit, no number; the forecaster's own chance of this, stated with the estimate: 85%; the middle value does not contradict the limit.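

In this assay compound 4 gives > 100 ug/mL, which is a limit and not a number. Among the compounds shown here, compound 1 stands at a limit too, and no step between compound 1 and compound 4 can be read. The compounds shown leave open whether inverting this one stereocentre changes the reading at all, because every reading shown stops at the same point: the limit of > 100 ug/mL in this assay, at which 4 of the 4 values shown sit.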